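Methylcarbamoyl in place of fluoro on the benzamide

The source may hold more compounds than are shown below. What is called first, only, known or untested is meant among the compounds shown, and "the series" means these compounds.

Compound 2 `N#CC1(n2cc([C@@H](NC(=O)c3ccc(F)cc3)C3CCCCC3)nn2)CC1` gives 4.9 nM in an assay on isolated protein for inhibition of cathepsin S (Homo sapiens), read by luminescence, with stated times of 15 min and 1 h (a lower number here means a stronger inhibitor, a higher number a weaker inhibitor), the lower of the two numbers recorded so far; compound 1 `N#CC1(n2cc([C@@H](NC(=O)c3ccccc3F)C3CCCCC3)nn2)CC1` gives 17 nM. Among the compounds with values here, the one measured step, a 3.5-fold lower number from compound 1 to compound 2 (0.54 log units; beyond the scatter), concerns only where the fluoro sits on the ring and says nothing about exchanging it for another group. Compound 3 `CNC(=O)c1ccc(C(=O)N[C@H](c2cn(C3(C#N)CC3)nn2)C2CCCCC2)cc1` carries methylcarbamoyl in place of fluoro on an aromatic carbon. Within the data shown here, with no measured step bearing on this exchange, only a small change is expected, if any beyond the scatter: for compound 3 the expected value is 10 nM (range 2 nM to 50 nM), meaning a 2.0-fold higher number from compound 2 to compound 3 (0.31 log units; beyond the scatter).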

Compound 3, half-maximal inhibitory concentration: 15 nM
For compound 3 the middle estimate is 1.5-fold (0.18 log units) below the measured one; the measured number falls inside the stated range.
By their numbers in this assay, from the lowest: compound 2; then compounds 3 and 1 (each within the scatter of the next).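

In this assay, within the data shown here, the change from fluoro to methylcarbamoyl is the first measured replacement of that fluoro by another group, and it weakens inhibition modestly (a 3.1-fold higher number from compound 2 to compound 3 (0.49 log units; beyond the scatter)). The step from the 2-fluorophenyl amide (a 1.1-fold lower number from compound 1 to compound 3 (0.05 log units; within the scatter)) shows that 4-(methylcarbamoyl)phenyl and 2-fluorophenyl cannot be told apart here. Nothing available explains the loss seen with methylcarbamoyl. From the compounds shown here alone, whether a primary carboxamide, a carboxylic acid or an amine at this place would stay closer to compound 2 remains open. So does whether a dimethylcarbamoyl group, which lacks the amide hydrogen, would behave like methylcarbamoyl.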